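Dropping the diethylamino group from compound 2

A few compounds are considered here, and "the series" means these few. Any claim that something is new, unique, unknown or untested is made for them only; others in the source may bear on it.

In a functional assay on HepG2 cells (Homo sapiens) for inhibition, read by MTT assay, with a stated time of 24 h (a higher number here means a weaker inhibitor, a lower number a stronger inhibitor), compound 2 `CCN(CC)c1ccc(/C=N/NC(=O)CNC(=O)c2ccc(F)cc2)c(OCc2ccccc2Cl)c1` gives > 50000 nM, which is a limit and not a number. Compound 3 `CCN(CC)c1ccc(/C=N/NC(=O)CNC(=O)c2ccc(C#N)cc2)c(OCc2ccccc2Cl)c1` gives > 50000 nM, which is also a limit. Compound 2 and compound 3 thus sit at the limit of > 50000 nM in this assay, at which 2 of the 3 values shown sit. For the measured compounds named here, the only measured step, a step that the two limits leave unreadable from compound 2 to compound 3, therefore offers no size to carry forward.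

Compound 4 `O=C(CNC(=O)c1ccc(F)cc1)N/N=C/c1ccccc1OCc1ccccc1Cl` differs from compound 2 in one place: hydrogen in place of diethylamino on an aromatic carbon. The best guide is compound 1 `Cc1ccc(C(=O)NCC(=O)N/N=C/c2ccccc2OCc2ccccc2Cl)cc1`, which also has no diethylamino group. In this assay compound 1 gives 13400 nM, a true number, so a measurable number is expected for compound 4 as well. This rests on a single compound, and a reading at the limit remains possible. The expected change is an at least 2.5-fold lower number from compound 2 to compound 4 (0.39 log units; beyond the scatter), in the direction of a lower number and so of stronger inhibition. For compound 4 the estimated value is 20000 nM, with an expected range of 8000 nM to 50000 nM.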

Compound 4, half-maximal inhibitory concentration: 24900 nM
For compound 4 the middle estimate is 1.2-fold (0.10 log units) below the measured one, and the stated range covers the measured number.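

In this assay, hydrogen in place of diethylamino gives an at least 2.0-fold lower number from compound 2 to compound 4 (0.30 log units; that floor lies within the scatter), so this aromatic carbon now has a step with a readable floor, and without the group the reading is a true number. Compound 2 gives only a limit, which leaves the full size of the step unknown: the limit of > 50000 nM in this assay, at which 2 of the 4 values shown sit. Among the compounds without diethylamino, fluoro in place of methyl on an aromatic carbon gives a 1.9-fold higher number from compound 1 to compound 4 (0.27 log units; within the scatter), so that swap separates neither compound from the other.

On these data alone, it remains open whether the whole diethylamino group or only part of it matters; a dimethylamino group, a simple amine or a methoxy group on this carbon could tell these apart. As far as these compounds go, it also remains open whether the cyano analogue without diethylamino would give a true number.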